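Replacing thiophen-3-yl with pyridin-2-yl

This account rests on a few compounds, and the source may have more. Where it says the series, first, only, none or still open, it means among the compounds named here.

In a functional assay on SW-620 cells (Homo sapiens) for antiproliferative activity, read by MTT assay, with a stated time of 24 h (a higher number here means a weaker inhibitor, a lower number a stronger inhibitor), compound 1 `COc1ccc(C(=O)/C=C/c2ccc(N(C)C)cc2)c2c1C=CC(C)(C)O2` gives 570 nM and compound 2 `COc1ccc(C(=O)/C=C/c2ccc([N+](=O)[O-])cc2)c2c1C=CC(C)(C)O2` gives 3520 nM. Compound 3 `COc1ccc(C(=O)/C=C/c2ccsc2)c2c1C=CC(C)(C)O2` gives > 10000 nM, which is a limit of the assay and not a number. Compound 4 `COc1ccc(C(=O)/C=C/c2ccccn2)c2c1C=CC(C)(C)O2` keeps the shared core and carries pyridin-2-yl in place of thiophen-3-yl on a double-bonded chain carbon bound to a double-bonded chain carbon.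

Two measured steps change the group at this same place. The first is an at least 17-fold higher number from compound 1 to compound 3 (1.24 log units; beyond the scatter), and the second is an at least 2.8-fold higher number from compound 2 to compound 3 (0.45 log units; beyond the scatter). Both show that this group can move the number beyond the scatter, but neither involves pyridin-2-yl. Compound 1 and compound 2 hold a six-membered aromatic ring here, as compound 4 does, so a move away from the limit seems plausible. The expected change is an at least 1.6-fold lower number from compound 3 to compound 4 (0.22 log units; that floor lies within the scatter), a small shift in this assay towards a stronger inhibitor that may not clear the scatter. For compound 4 the estimated value is 6000 nM, with an expected range of 1800 nM to 15000 nM.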

Compound 4, half-maximal inhibitory concentration: 5000 nM
Compound 4: the middle estimate sits 1.2-fold (0.08 log units) above what was measured; the measured number falls inside the stated range.
By their numbers in this assay, from the lowest: compound 1; then compounds 2 and 4 (each within the scatter of the next). At a limit, above all of these: compound 3.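

Compound 3 is held at a limit and not a number: the limit of > 10000 nM in this assay, at which 1 of the 4 values shown sits. In this assay the change can therefore be read only as a floor, an at least 2.0-fold lower number from compound 3 to compound 4 (0.30 log units; that floor lies within the scatter), and pyridin-2-yl gives this place its first measured number for a ring with a hetero atom. Pyridin-2-yl and 4-nitrophenyl stay level, with a 1.4-fold higher number from compound 2 to compound 4 (0.15 log units; within the scatter), while the change from 4-(dimethylamino)phenyl is clear, with an 8.8-fold higher number from compound 1 to compound 4 (0.94 log units; beyond the scatter), so among these compounds a six-membered aromatic ring alone does not match compound 1.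

Going by these compounds, whether compound 1 owes its number to dimethylamino itself stays open, and a smaller amine or a methoxy group on that phenyl ring would offer the comparison. Also open, on these data alone, is how a plain phenyl ring, carrying no added group, would compare with pyridin-2-yl.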